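Benzylamino to Butylamino: Cytotoxicity Expected for Compound 4

A few compounds are considered here, and "the series" means these few. Any claim that something is new, unique, unknown or untested is made for them only; others in the source may bear on it.

Compound 1, `Nc1nc(NCc2ccccc2)c2ncn(/C=C3/CC3(CO)CO)c2n1`, gives > 24000 nM in an ADME assay on Akata cells (Homo sapiens) for cytotoxicity, with a stated time of 7 days (on this read-out higher numbers stand for lower toxicity in this test and lower numbers for higher toxicity in this test), which is a limit.
Compound 2, `CSc1nc(N)nc2c1ncn2/C=C1/CC1(CO)CO`, gives > 20000 nM in this assay, which is a limit.
Compound 3, `Nc1nc(SC2CCCC2)c2ncn(/C=C3/CC3(CO)CO)c2n1`, gives > 20000 nM in this assay, which is a limit.

Compound 1 therefore stands only at a limit of this assay, not at a number, so its place relative to compounds 2 and 3 cannot be read; those two values are limits as well. Compound 4, `CCCCNc1nc(N)nc2c1ncn2/C=C1/CC1(CO)CO`, differs from compound 1 by propyl in place of phenyl on a saturated chain carbon bound to a nitrogen on an aromatic ring. The measured steps that touch the same part of the shared core are a step that the two limits leave unreadable from compound 1 to compound 2, a step that the two limits leave unreadable from compound 1 to compound 3 and a step that the two limits leave unreadable from compound 2 to compound 3, and none of them has a readable size, because the limit of > 20000 nM in this assay, at which 2 of the 3 values shown sit, and the limit of > 24000 nM in this assay, at which 1 of the 3 values shown sits, are where every measured value sits. They show only that none of the three measured compounds reached a half-maximal cytotoxic concentration within the tested range. With no readable step to lean on, no change beyond the scatter is expected from compound 1 to compound 4, and a further limit is the most likely outcome. Compound 4 is therefore expected to give about 24000 nM in this assay, with a likely range from 12000 nM to 60000 nM. The expected step is a number no higher from compound 1 to compound 4 (the limit leaves the size open).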

Compound 4, half-maximal cytotoxic concentration: > 24000 nM
Compound 4: only a limit was reported; the forecaster's own chance of this, stated with the estimate: 85%; the middle value sits exactly at the limit.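

Compound 4 sits at a limit, and so does compound 1: the limit of > 24000 nM in this assay, at which 2 of the 4 values shown sit. Compound 2 and compound 3 sit at a limit too: the limit of > 20000 nM in this assay, at which 2 of the 4 values shown sit. Going by these compounds alone, no step from compound 1, compound 2 or compound 3 to compound 4 can therefore be read in this assay. As far as these compounds go, what stays open is the concentration at which any of these four compounds would reach half-maximal cytotoxicity.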